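A few compounds are considered here, and "the series" means these few. Any claim that something is new, unique, unknown or untested is made for them only; others in the source may bear on it.

Three compounds have been measured in an ADME assay on MT4 cells (Homo sapiens) for cytotoxicity, read by MTT assay, with a stated time of 5 days; on this read-out lower numbers stand for higher toxicity in this test and higher numbers for lower toxicity in this test:

compound 1, `CCNC(c1ccc(/C=C/C#N)cc1)c1ccnc(Nc2ccc(C#N)cc2)n1`, gives 37300 nM
compound 2, `CCCNC(c1ccc(/C=C/C#N)cc1)c1ccnc(Nc2ccc(C#N)cc2)n1`, gives 34000 nM
compound 3, `N#C/C=C/c1ccc(C(NC2CC2)c2ccnc(Nc3ccc(C#N)cc3)n2)cc1`, gives 56100 nM

Compound 3 stands at the highest of the three numbers shown, but its neighbours sit close: a 1.5-fold higher number from compound 1 to compound 3 (0.18 log units; within the scatter) and a 1.7-fold higher number from compound 2 to compound 3 (0.22 log units; within the scatter). Both steps lie within the scatter, so no order among the three can be read from them; the same holds for a 1.1-fold lower number from compound 1 to compound 2 (0.04 log units; within the scatter).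

Compound 4, `N#C/C=C/c1ccc(C(NN)c2ccnc(Nc3ccc(C#N)cc3)n2)cc1`, has not yet been measured. It differs from compound 3 in one place: amino in place of cyclopropyl on an amine nitrogen. The two steps that bear on this change are those that also alter the group on this amine nitrogen, from ethyl or propyl to cyclopropyl, and each stayed within the scatter. Neither, however, brings in amino, so the change is not covered directly, and the expectation rests on the quiet behaviour of this position alone. The step of a 1.2-fold lower number from compound 3 to compound 4 (0.10 log units; within the scatter) is therefore expected to remain within the scatter, with no direction favoured. In this assay compound 4 is estimated at 45000 nM, with a range from 18000 nM to 110000 nM.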

Compound 4, half-maximal cytotoxic concentration: 186000 nM
Compound 4: the middle estimate sits 4.1-fold (0.62 log units) below what was measured; the measured number lies above the stated range.
By their numbers in this assay, from the lowest: compounds 2, 1 and 3 (each within the scatter of the next); then compound 4.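

In this assay the group on this amine nitrogen can move the number after all: amino in place of cyclopropyl gives (a 3.3-fold higher number from compound 3 to compound 4 (0.52 log units; beyond the scatter)), and amino in place of the two chains gives (a 5.5-fold higher number from compound 2 to compound 4 (0.74 log units; beyond the scatter)) and (a 5.0-fold higher number from compound 1 to compound 4 (0.70 log units; beyond the scatter)). All three steps run towards lower toxicity in this test, whereas ethyl, propyl and cyclopropyl stayed within the scatter of one another, so the position is quiet among these three carbon groups but not for every group placed on it. Nothing available here accounts for the higher number seen with amino.

Compound 4 is the only compound shown with a nitrogen group at this place, so it remains open whether the shift belongs to amino alone. From the compounds shown here alone, a methylamino or hydroxyl group on this amine nitrogen would test that, and whether the step holds on a changed core also remains open.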